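The source may hold more compounds than are shown below. What is called first, only, known or untested is meant among the compounds shown, and "the series" means these compounds.

In a functional assay on EBC-1 cells (Homo sapiens) for antiproliferative activity, read by sulforhodamine B assay, with a stated time of 72 h (on this read-out higher numbers stand for weaker inhibition and lower numbers for stronger inhibition), compound 1 (`Cn1cc(-c2ccc(=O)n(CCOc3ccnc4cc(OCCCCCCC(=O)NO)ccc34)n2)cn1`) gives 210 nM and compound 2 (`CNC(=O)CCCCCOc1ccc2c(OCCn3nc(-c4cnn(C)c4)ccc3=O)ccnc2c1`) gives 79 nM. Compound 2 therefore holds the lower of the two numbers. The next compound, compound 3 (`Cn1cc(-c2ccc(=O)n(CCOc3ccnc4cc(C(=O)Nc5ccccc5N)ccc34)n2)cn1`), keeps the shared core but differs from compound 2 at one place: (2-aminophenyl)carbamoyl in place of (5-(methylcarbamoyl)pentyl)oxy on an aromatic carbon. The new group, (2-aminophenyl)carbamoyl, replaces (5-(methylcarbamoyl)pentyl)oxy on an aromatic carbon.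

For the measured compounds named here, only one measured step bears on this change, and only indirectly. That step, a 2.7-fold lower number from compound 1 to compound 2 (0.42 log units; beyond the scatter), is modest, though beyond the scatter, and it alters only the end of the chain. Here the whole (5-(methylcarbamoyl)pentyl)oxy group leaves, and no measured compound carries the entering group, so the data give no direct guide to this replacement. With the modest step as the only yardstick, a change of similar size is expected in this assay, leaning towards a higher number. The expected step is a 1.9-fold higher number from compound 2 to compound 3 (0.28 log units; within the scatter). For compound 3 the estimated value is 150 nM, with an expected range from 40 nM to 600 nM.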

Compound 3, half-maximal inhibitory concentration: > 10000 nM
Compound 3 gave a limit, no number (the forecaster's own chance of this, stated with the estimate: 3%); middle value at least 66-fold (1.82 log units) from the limit.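

Compound 3 carries a limit of the assay and not a number: the limit of > 10000 nM in this assay, at which 1 of the 3 values shown sits. In this assay the position on the aromatic carbon proves far from indifferent: the exchange of (5-(methylcarbamoyl)pentyl)oxy for (2-aminophenyl)carbamoyl gives an at least 120-fold higher number from compound 2 to compound 3 (2.10 log units; beyond the scatter), and the exchange of (6-(hydroxycarbamoyl)hexyl)oxy for the same group gives an at least 47-fold higher number from compound 1 to compound 3 (1.67 log units; beyond the scatter). Altering only the end of the chain had produced a modest step, a 2.7-fold lower number from compound 1 to compound 2 (0.42 log units; beyond the scatter), so both chain-bearing compounds keep measured values, while removing the whole chain in favour of the (2-aminophenyl)carbamoyl group has a large effect that the earlier pair could not reveal.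

Since this exchange replaces the ether oxygen, the chain and its end all at once, the compounds shown do not separate the loss of the chain from the arrival of the aminophenyl amide, and the true size of the step stays unknown beyond its limit. As far as these compounds go, it remains open whether the 2-aminophenyl amide placed at the end of a hexyl ether chain, or a shorter chain ending in a primary amine or a carboxylic acid, would return a measurable value at this position.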